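An ethyl in place of pyridin-3-yl on the ring nitrogen

The compounds below may be only part of what the source reports. "The series", "measured", "known", "first", "only" and "open" are said of these compounds alone.

Three compounds have been measured in an assay on isolated protein for inhibition of methionine--tRNA ligase, cytoplasmic (Homo sapiens); on this read-out lower numbers stand for stronger inhibition and higher numbers for weaker inhibition:
compound 1 `O=C(O)c1cc(-c2ccc(-c3ccc(Cl)cc3Cl)cc2)n(-c2cccnc2)n1` gives 47000 nM.
compound 2 `O=C(O)c1cc(-c2ccc(-c3ccc(Cl)cc3Cl)cc2)n(-c2ccccn2)n1` reaches only the limit > 100000 nM.
compound 3 `O=C(O)c1cc(-c2ccc(-c3ccc(Cl)cc3Cl)cc2)nn1Cc1ccccn1` gives 22300 nM.

Compound 1 stands highest of the two numbers; compound 3, the nearest, gives a lower number, beyond the scatter. For compound 2 the result is a limit, not a number, (the limit of > 100000 nM in this assay, at which 1 of the 3 values shown sits). For the measured compounds named here, the one measured step at the aromatic nitrogen, an at least 2.1-fold higher number from compound 1 to compound 2 (0.32 log units; beyond the scatter), follows from pyridin-2-yl in place of pyridin-3-yl on that nitrogen and weakens inhibition.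

Compound 4 `CCn1nc(C(=O)O)cc1-c1ccc(-c2ccc(Cl)cc2Cl)cc1` differs from compound 1 by ethyl in place of pyridin-3-yl on an aromatic nitrogen. Going by the values given here, no measured step exchanges the aromatic group on this nitrogen for a short chain, so the step to compound 2 bears on it only as a sign that this position is sensitive to change, and compound 3 shows that a different group there can also give a lower number than compound 1. Among the compounds with values here, with no closer precedent, no step beyond the scatter is expected in this assay, and the estimate for the step of a 1.0-fold lower number from compound 1 to compound 4 (0.02 log units; within the scatter) is held near zero with a wide range. Compound 4 is therefore estimated at 45000 nM, between 15000 nM and 150000 nM.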

Compound 4, half-maximal inhibitory concentration: 46400 nM
Compound 4: middle estimate off by 1.0-fold (0.01 log units), on the low side; the range from low to high includes it.
By their numbers in this assay, from the lowest: compound 3; then compounds 4 and 1 (each within the scatter of the next). At a limit, above all of these: compound 2.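

In this assay, the pyridin-3-yl ring on this aromatic nitrogen, with its hydrogen-bond acceptor, can give way to ethyl, which has no ring and no acceptor, and the result stays within the scatter: a 1.0-fold lower number from compound 1 to compound 4 (0.01 log units; within the scatter). The other step reads differently, with an at least 2.1-fold lower number from compound 2 to compound 4 (0.33 log units; beyond the scatter), so among the three groups compared directly on this nitrogen, pyridin-2-yl is the one that stands apart, while ethyl and pyridin-3-yl cannot be told apart on this read-out. The result for compound 2 is a limit and not a number, so the size of that step is known only from one side: the limit of > 100000 nM in this assay, at which 1 of the 4 values shown sits.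

The compounds shown leave open how a longer chain such as butyl, or a chain ending in an amine, would read on this nitrogen in this assay. They also leave open whether a plain phenyl ring there would sit with pyridin-3-yl and ethyl or with pyridin-2-yl.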